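Cyano for methyl on the pyrazole of compound 2

This account rests on a few compounds, and the source may have more. Where it says the series, first, only, none or still open, it means among the compounds named here.

Measured compounds:
compound 1, `COc1cc(-c2c(C)nn(C)c2C)ccc1-c1nnc(N(C)Cc2ccc3nccn3c2)o1`, 794 nM in an assay on isolated protein for inhibition of tyrosine-protein kinase receptor UFO (Homo sapiens), read by LC-MS; a higher number here means a weaker inhibitor, a lower number a stronger inhibitor
compound 2, `Cc1cc(-c2c(C)nn(C)c2C)ccc1-c1nnc(N(C)Cc2ccc3nccn3c2)o1`, 79.4 nM in this assay
compound 3, `Cc1nn(C)c(C)c1-c1ccc(-c2nnc(N(C)Cc3ccc4nccn4c3)o2)c(C#N)c1`, a limit of > 100000 nM in this assay

Compound 2 sits lowest of the two numbers in this assay; the nearest number belongs to compound 1, and the step of a 10-fold lower number from compound 1 to compound 2 (1.00 log units; beyond the scatter) lies beyond the scatter. Compound 3 returns only a limit, (the limit of > 100000 nM in this assay, at which 1 of the 3 values shown sits).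

Compound 4, `Cc1cc(-c2c(C#N)nn(C)c2C)ccc1-c1nnc(N(C)Cc2ccc3nccn3c2)o1`, differs from compound 2 by cyano in place of methyl on an aromatic carbon, that is, 1,3,5-trimethyl-1H-pyrazol-4-yl becomes 3-cyano-1,5-dimethyl-1H-pyrazol-4-yl. Going by the values given here, the steps that bear on it are both cyano replacements on an aromatic carbon, though on a different ring: an at least 1200-fold higher number from compound 2 to compound 3 (3.10 log units; beyond the scatter) and an at least 120-fold higher number from compound 1 to compound 3 (2.10 log units; beyond the scatter), both large and ending at a limit. Since these sit on another ring, the transfer is uncertain, but a higher number in this assay is the expectation for compound 4, of modest to large size.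

Compound 4 is expected at 800 nM, with a range from 150 nM to 6000 nM. The expected step is a 10-fold higher number from compound 2 to compound 4 (1.00 log units; beyond the scatter).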

Compound 4, half-maximal inhibitory concentration: 6310 nM
Compound 4: middle estimate off by 7.9-fold (0.90 log units), on the low side, and the stated range ends below it.
By their numbers in this assay, from the lowest: compound 2; then compound 1; then compound 4. At a limit, above all of these: compound 3.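

In this assay, replacing methyl with cyano at this position on the pyrazole is costly, a 79-fold higher number from compound 2 to compound 4 (1.90 log units; beyond the scatter), so the methyl here cannot be exchanged for cyano without a large penalty. The earlier cyano steps were on a different ring and ended at a limit, whereas this step has a measured endpoint and gives the first actual size for a cyano replacement in the series. Compound 3 remains a limit and not a number: the limit of > 100000 nM in this assay, at which 1 of the 4 values shown sits.

The compounds shown leave open whether this step belongs to cyano itself or would follow any replacement of this methyl. A hydrogen, a chlorine or a hydroxymethyl group at the same position would separate these two readings.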